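The compounds below may be only part of what the source reports. "The series", "measured", "known", "first", "only" and "open" are said of these compounds alone.

Compound 1 `Oc1cccc(-c2cc(-c3ccc(OC(F)(F)F)cc3)cc(-c3ccccc3O)n2)c1` is the starting point of this small set. In a functional assay on HeLa cells (Homo sapiens) for inhibition (on this read-out lower numbers stand for stronger inhibition and higher numbers for weaker inhibition), compound 1 gives 20600 nM. Compound 2 `Oc1ccc(-c2cc(-c3ccc(OC(F)(F)F)cc3)cc(-c3ccccc3O)n2)cc1` carries 4-hydroxyphenyl in place of 3-hydroxyphenyl on an aromatic carbon. For compound 2 in this assay only a limit is reported, > 50000 nM, and that is a limit of the assay (the limit of > 50000 nM in this assay, at which 1 of the 3 values shown sits). The step is therefore an at least 2.4-fold higher number from compound 1 to compound 2 (0.38 log units; beyond the scatter). Compound 3 `Oc1cccc(-c2cc(-c3ccccc3OC(F)(F)F)cc(-c3cccc(O)c3)n2)c1` has a core that differs from that of compound 1, and how the two cores differ is not broken down here. In this assay compound 3 gives 16700 nM, a value that lies within the scatter of the value of compound 1. Compound 4 `Oc1ccc(-c2cc(-c3ccccc3OC(F)(F)F)cc(-c3cccc(O)c3)n2)cc1` stands to compound 3 as compound 2 stands to compound 1 (4-hydroxyphenyl in place of 3-hydroxyphenyl on an aromatic carbon), the same kind of change rather than the same one, since the place is meta to a 3-hydroxyphenyl group in compound 3 but meta to a 2-hydroxyphenyl group in compound 1. Resting on compound 1 and the step of an at least 2.4-fold higher number from compound 1 to compound 2 (0.38 log units; beyond the scatter), the step from compound 3 is expected to be a 2.7-fold higher number from compound 3 to compound 4 (0.43 log units; beyond the scatter). Compound 4 is therefore estimated at 45000 nM in this assay, between 20000 nM and 100000 nM.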

Compound 4, half-maximal inhibitory concentration: 5800 nM
Beside the measured number, compound 4's estimate is 7.8-fold (0.89 log units) above it; the measured number lies below the stated range.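

In this assay, 4-hydroxyphenyl in place of 3-hydroxyphenyl gives a 2.9-fold lower number from compound 3 to compound 4 (0.46 log units; beyond the scatter), so on this core the change goes with a lower number, not the higher one seen on the core of compound 1. The change therefore does not carry from one core to the other, even in its direction: the same change on two cores in this assay, an at least 2.4-fold higher number (0.38 log units; beyond the scatter) from compound 1 to compound 2 and a 2.9-fold lower number (0.46 log units; beyond the scatter) from compound 3 to compound 4, at least 6.9-fold (0.84 log units) apart, beyond the scatter of two such steps

Compound 2 is reported only as a limit, so the earlier step has no exact size, and the two cores do not show which difference between them decides the outcome: the limit of > 50000 nM in this assay, at which 1 of the 4 values shown sits.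

From the compounds shown here alone, whether the same change would raise or lower the number on a further core remains open, and two cores cannot show which direction is the more usual. Also open, going by these compounds, is how an amine or a carboxylic acid in place of the hydroxyl of the hydroxyphenyl group would read in this assay.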